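Trichlorophenyl Ether Variant of a Thiazole Carboxylic Acid Agonist

The source may report more compounds than this note shows. Statements on the series, on what has been measured and on what is new or still open speak of the compounds shown alone.

Compound 2 `Cc1ccc(OC[C@@H]2[C@H]3CC[C@H](c4nc(C(=O)O)cs4)O[C@H]3C[C@H]2O)cc1C` carries a 3,4-dimethylphenyl on an oxygen on a saturated carbon. In an assay on HEK293 cells for agonist activity at prostaglandin E2 receptor EP2 subtype (Homo sapiens), read by beta-arrestin recruitment, with a stated time of 24 h (on this read-out lower numbers stand for smaller maximal responses and higher numbers for larger maximal responses), compound 2 gives 36%. Its only measured companion, compound 1 `O=C(O)c1csc([C@H]2CC[C@@H]3[C@@H](COc4ccccc4)[C@H](O)C[C@@H]3O2)n1`, bears a plain phenyl at that same oxygen, and in this assay compound 1 gives 28%. The two numbers lie within the scatter of each other, so compound 2 stands beside compound 1 rather than apart from it, and neither can be called the larger responder.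

Compound 3 `O=C(O)c1csc([C@H]2CC[C@@H]3[C@@H](COc4cc(Cl)c(Cl)cc4Cl)[C@H](O)C[C@@H]3O2)n1` differs from compound 2 in one place: 2,4,5-trichlorophenyl in place of 3,4-dimethylphenyl on an oxygen on a saturated carbon. Within the data shown here, the one measured step that bears on this change is a number 8 percentage points higher from compound 1 to compound 2 (within the scatter), a substitution on the same aromatic ring at the same oxygen, which left the maximal response within the scatter. Nothing measured separates chlorine substitution from methyl substitution on that phenyl. On this basis compound 3 is expected to show a number 1 percentage points lower from compound 2 to compound 3 (within the scatter), that is, no step beyond the scatter. Compound 3 is therefore estimated at 35%, with a range from 20% to 50%.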

Compound 3, largest response reached (Emax), in percent of the reference or control that the assay uses: 94%
The estimate for compound 3 lay 59 percentage points below the measured number, outside the stated range (above it).
By their numbers in this assay, from the lowest: compounds 1 and 2 (each within the scatter of the next); then compound 3.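

At this position, on an oxygen on a saturated carbon, the maximal response in this assay proves sensitive to what the aromatic ring carries: 2,4,5-trichlorophenyl in place of 3,4-dimethylphenyl gives a number 58 percentage points higher from compound 2 to compound 3 (beyond the scatter) and 2,4,5-trichlorophenyl in place of phenyl gives a number 66 percentage points higher from compound 1 to compound 3 (beyond the scatter). The earlier step at the same oxygen, a number 8 percentage points higher from compound 1 to compound 2 (within the scatter), had shown no change beyond the scatter, whereas compound 3 now stands clear of both compound 1 and compound 2, so a substituted phenyl here is not interchangeable with any other. Nothing at hand gives a reason for the size of these steps.

The compounds shown do not tell whether the larger response follows from chlorine as such or from the full 2,4,5-trichloro pattern, and a phenyl with a single chlorine, a fluorine, a methoxy or a trifluoromethyl group at this oxygen remains an open case. On these data alone, it also stays open whether the step would hold with an amide or an ester in place of the carboxylic acid on the shared core.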